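The compounds below may be only part of what the source reports. "The series", "measured", "known", "first", "only" and "open" are said of these compounds alone.

Two compounds have been measured in a functional assay on HEK293 cells for negative allosteric modulation of metabotropic glutamate receptor 5 (Homo sapiens), read by HTRF and inositol phosphate accumulation; on this read-out higher numbers stand for weaker inhibition and lower numbers for stronger inhibition:

compound 1 `CCCC[C@@H](NC(=O)c1nccs1)c1cnc(Nc2ccc(C)nc2)c(Cl)c1`, 30.9 nM;
compound 2 `Cc1ccc(Nc2ncc([C@H](NC(=O)c3nccs3)C(C)C)cc2Cl)cn1`, 7.5 nM.

Compound 2 gives the lowest of the two numbers, and in this assay its gap to compound 1 lies beyond the usual scatter. Among the compounds with values here, the only measured step, a 4.1-fold lower number from compound 1 to compound 2 (0.61 log units; beyond the scatter), shows that replacing butyl with isopropyl on the saturated chain carbon bound to an amide-type nitrogen and an aromatic carbon strengthened inhibition modestly. Compound 3 `Cc1ccc(Nc2ncc([C@H](NC(=O)c3nccs3)C3CC3)cc2Cl)cn1` carries the change (cyclopropyl in place of isopropyl on a saturated chain carbon bound to an amide-type nitrogen and an aromatic carbon). Cyclopropyl and isopropyl are close in what they contribute, and no measured pair shows this particular swap, so the expectation rests on compound 2 alone. Because the step of a 4.1-fold lower number from compound 1 to compound 2 (0.61 log units; beyond the scatter) already favoured the smaller branched group, compound 3 is expected to show a step of a 1.3-fold lower number from compound 2 to compound 3 (0.10 log units; within the scatter) that stays within the scatter. In this assay compound 3 is estimated at 6 nM, within a range from 2 nM to 20 nM.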

Compound 3, half-maximal inhibitory concentration: 9.7 nM
Compound 3: the middle estimate sits 1.6-fold (0.21 log units) below what was measured, and the stated range covers the measured number.
By their numbers in this assay, from the lowest: compounds 2 and 3 (each within the scatter of the next); then compound 1.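

In this assay, closing the isopropyl group into a cyclopropyl ring at the saturated chain carbon bound to an amide-type nitrogen and an aromatic carbon gives a step within the scatter (a 1.3-fold higher number from compound 2 to compound 3 (0.11 log units; within the scatter)), so the two groups cannot be told apart on this read-out. Cyclopropyl in place of butyl gives a step beyond the scatter (a 3.2-fold lower number from compound 1 to compound 3 (0.50 log units; beyond the scatter)), which means that compound 2 and compound 3, with a group of 3 carbons with or without a ring, both give lower numbers than compound 1 with its butyl chain. Nothing shown here explains these numbers.

Still open, on these data alone, is how much larger a group this carbon tolerates before the numbers rise, as a cyclobutyl ring or a tert-butyl group would test. A smaller methyl group, or a chain ending in an amine, would show whether the trend continues with a different kind of group.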